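Compound 4: an ester becomes an acid

The source may report more compounds than this note shows. Statements on the series, on what has been measured and on what is new or still open speak of the compounds shown alone.

Compound 1 `CN1CCN(C(=O)/C=C/c2ccncc2-c2ccc3ccccc3c2)CC1` gives > 10000 nM as a limit
Compound 2 `CCOC(=O)/C=C/c1ccncc1-c1ccc2c(cnn2C)c1` gives > 10000 nM as a limit
Compound 3 `CCOC(=O)/C=C/c1ccncc1-c1ccc2[nH]ccc2c1` gives > 10000 nM as a limit

All three compounds were tested in a functional assay on KB cells (Homo sapiens) for inhibition, read by sulforhodamine B assay, with a stated time of 72 h (on this read-out lower numbers stand for stronger inhibition of growth and higher numbers for weaker inhibition of growth), and none gave an exact number. Compound 2 stands at > 10000 nM as a limit of the assay, not a number. The whole set looks the same, with the limit of > 10000 nM in this assay, at which 3 of the 3 values shown sit, and nothing to rank the compounds by.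

Compound 4 `Cn1ncc2cc(-c3cnccc3/C=C/C(=O)O)ccc21` alters compound 2 in a single place, counted as hydrogen in place of ethyl on an oxygen next to a carbonyl group in this change: hydrogen in place of ethyl on an oxygen next to a carbonyl group, so ethoxycarbonyl becomes carboxy. Among the measured compounds shown here, no measured pair shows a comparable change. The expected step that the limit leaves unreadable from compound 2 to compound 4 is none beyond the scatter. In this assay compound 4 is estimated at 12000 nM (expected range 5000 nM to 30000 nM).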

Compound 4, concentration for 50% growth inhibition: > 10000 nM
Compound 4: no number, only a limit; the forecaster's own chance of this, stated with the estimate: 85%; the middle value lies beyond the limit too.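

No step can be read from compound 2 to compound 4, because both stop at a limit of the assay: the limit of > 10000 nM in this assay, at which 4 of the 4 values shown sit.

The compounds shown leave open how strongly any of them inhibits growth, and whether hydrogen in place of ethyl changes that at all.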